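The source may report more compounds than this note shows. Statements on the series, on what has been measured and on what is new or still open speak of the compounds shown alone.

Working notes on the series. Of the three measured compounds, compound 1 `CCCCCNc1ncnc2c1ncn2[C@@H]1O[C@H](CO)[C@@H](O)[C@H]1O` stands lowest in an assay on isolated protein for binding affinity to Equilibrative nucleoside transporter 1 (Homo sapiens) (a lower number here means a stronger inhibitor, a higher number a weaker inhibitor), where compound 1 gives 13500 nM. Compound 3 `CCCn1cnc2c(SC(C)C)nc(N)nc21` gives 145000 nM in this assay, and compound 2 `Nc1ncnc2c1ncn2[C@@H]1O[C@H](COCCOCCNc2ncnc3c2ncn3[C@@H]2O[C@H](CO)[C@@H](O)[C@H]2O)[C@@H](O)[C@H]1O` gives 912000 nM; both gaps to compound 1 lie beyond the scatter. Compound 4 `OC[C@H]1O[C@@H](n2cnc3c(CSc4cccc(I)c4)ncnc32)[C@H](O)[C@@H]1O` has not yet been measured. Its change from compound 1 is a group of 9 heavy atoms (7 carbon, 1 sulfur, 1 iodine; one six-membered aromatic ring of carbon only) in place of a group of 6 heavy atoms (5 carbon, 1 nitrogen; no ring), on an aromatic carbon. Going by the values given here, no measured pair in this set covers a change of this kind, so the direction rests on expectation alone. Starting from the value of compound 1 in this assay, 13500 nM, a large step down is expected, a 230-fold lower number from compound 1 to compound 4 (2.35 log units; beyond the scatter), well beyond the scatter. Compound 4 is estimated at 60 nM in this assay, within a range from 5 nM to 800 nM.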

Compound 4, half-maximal inhibitory concentration: 245 nM
Estimate against measurement, compound 4: 4.1-fold (0.61 log units) below; low and high end bracket the measured number.
By their numbers in this assay, from the lowest: compound 4; then compound 1; then compound 3; then compound 2.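

In this assay, the step of a 55-fold lower number from compound 1 to compound 4 (1.74 log units; beyond the scatter) shows that this aromatic carbon accepts a group with a six-membered aromatic ring of carbon only, carrying sulfur and iodine, in place of pentylamino. It also shows that the hydrogen-bond donor of pentylamino is not required for a low number here. No measurement bears on the reason for this step. Ring, sulfur and iodine all enter together, so the share of each remains open. A phenylthiomethyl group without iodine, or a hexyl chain, would help separate them.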